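Indolyl to methoxyphenyl swap in the growth-inhibition series

The compounds below may be only part of what the source reports. "The series", "measured", "known", "first", "only" and "open" are said of these compounds alone.

Compound 1 `Cc1ccc(S/C(=C/c2c[nH]c3ccccc23)C(=O)c2ccc(Br)cc2)cc1`: 10000 nM
Compound 2 `O=C(/C(=C\c1ccc(O)c([N+](=O)[O-])c1)SCc1ccc(Cl)cc1)c1ccc(Cl)cc1`: 10000 nM

In a functional assay on DU-145 cells (Homo sapiens) for inhibition, read by trypan blue exclusion, with a stated time of 96 h (a higher number here means a weaker inhibitor of growth, a lower number a stronger inhibitor of growth), compound 1 gives 10000 nM and stands level with compound 2, within the scatter. Compound 3 `COc1ccc(/C=C(/Sc2ccc(C)cc2)C(=O)c2ccc(Br)cc2)cc1` has not yet been measured. It differs from compound 1 by 4-methoxyphenyl in place of 1H-indol-3-yl on a double-bonded chain carbon bound to a double-bonded chain carbon, with 4-methoxyphenyl in place of 1H-indol-3-yl on a double-bonded chain carbon bound to a double-bonded chain carbon. Going by the values given here, no measured pair shows this change, so the expectation is loose. The expected step is a 2.5-fold lower number from compound 1 to compound 3 (0.40 log units; beyond the scatter), a moderate fall in the number in this assay, meaning stronger inhibition of growth, though no change beyond the scatter remains possible. For compound 3 the estimated value is 4000 nM, with an expected range of 400 nM to 15000 nM.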

Compound 3, concentration for 50% growth inhibition: 50000 nM
Beside the measured number, compound 3's estimate is 13-fold (1.10 log units) below it, and the stated range ends below it.
By their numbers in this assay, from the lowest: compounds 1 and 2 (each within the scatter of the next); then compound 3.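

On a double-bonded chain carbon bound to a double-bonded chain carbon, 4-methoxyphenyl in place of 1H-indol-3-yl gives a 5.0-fold higher number from compound 1 to compound 3 (0.70 log units; beyond the scatter) in this assay and so weakens inhibition of growth. This place is therefore sensitive to the group it carries, and of these two groups 1H-indol-3-yl gives the stronger inhibitor. Nothing measured accounts for the step.

As far as these compounds go, whether a phenyl bearing a dimethylamino group or a carboxylic acid at this place would match 1H-indol-3-yl stays open. Compound 2 differs from compound 3 in more than one place, so it adds nothing on this change.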